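The source may report more compounds than this note shows. Statements on the series, on what has been measured and on what is new or still open speak of the compounds shown alone.

Within the data shown here, in a functional assay on MGC-803 cells (Homo sapiens) for inhibition, read by MTT assay, with a stated time of 48 h (a higher number here means a weaker inhibitor, a lower number a stronger inhibitor), three compounds built on a shared core have numbers so far: compound 1 (`CCOC(=O)c1ccc(Nc2nnc(Cl)c(Nc3cc(OC)c(OC)c(OC)c3)n2)cc1`) gives 53600 nM, compound 2 (`COc1cccc(Nc2nnc(Cl)c(Nc3cc(OC)c(OC)c(OC)c3)n2)c1`) gives 16500 nM, and compound 3 (`COc1cc(Nc2nc(Nc3ccc(Br)cc3)nnc2Cl)cc(OC)c1OC`) gives 11400 nM. One step, a 1.4-fold lower number from compound 2 to compound 3 (0.16 log units; within the scatter), stays within the scatter, so these two stand together at the low end of the numbers. The other, a 4.7-fold lower number from compound 1 to compound 3 (0.67 log units; beyond the scatter), is modest.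

Compound 4 (`COc1cc(Nc2nc(Nc3ccc(C(C)=O)cc3)nnc2Cl)cc(OC)c1OC`) keeps the core of compound 3 and differs by acetyl in place of bromo on an aromatic carbon. The step from compound 2 changes the position of the substituent as well as its identity, so it says little here. The closer guide is compound 1, which carries ethoxycarbonyl at that same place and, like acetyl, contains a carbonyl. Among the measured compounds shown here, with only this one comparison, a partial return towards compound 1 is expected in this assay. The expected change is a 2.1-fold higher number from compound 3 to compound 4 (0.32 log units; beyond the scatter), a modest rise. For compound 4 the estimate is 24000 nM, with an expected range of 9000 nM to 60000 nM.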

Compound 4, half-maximal inhibitory concentration: 13000 nM
For compound 4 the middle estimate is 1.8-fold (0.27 log units) above the measured one, within the range that was stated.
By their numbers in this assay, from the lowest: compounds 3, 4 and 2 (each within the scatter of the next); then compound 1.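

In this assay, acetyl serves as well as bromo at this place, para to a large group, with a 1.1-fold higher number from compound 3 to compound 4 (0.06 log units; within the scatter), so a carbonyl at this position does not by itself carry the number towards that of compound 1. The ethoxy on the carbonyl carbon marks the larger difference, since replacing it with methyl gives a 4.1-fold lower number from compound 1 to compound 4 (0.62 log units; beyond the scatter), while a 1.3-fold lower number from compound 2 to compound 4 (0.10 log units; within the scatter) leaves compounds 2, 3 and 4 together. Nothing measured here explains why these groups give these numbers.

From the compounds shown here alone, it remains open whether a carboxylic acid, an amine or a longer ester chain at this same place would stay with compounds 3 and 4 or move towards compound 1. The chloro on the shared core is the same in all four compounds, so the effect of replacing it with an amine or a methyl group is also unknown.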